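The source may hold more compounds than are shown below. What is called first, only, known or untested is meant among the compounds shown, and "the series" means these compounds.

Compound 1 `Cc1ccccc1C#Cc1ccc(C(=O)N[C@H](C)C(C)(C)O)nc1` and compound 2 `CC(C)CNC(=O)c1ccc(C#Cc2cccc(F)c2)cn1` share the same core and differ in the groups hanging off it. In a functional assay on HEK293 cells for positive allosteric modulation of metabotropic glutamate receptor 5 (Rattus norvegicus), read by fluorescence and calcium flux (on this read-out higher numbers stand for larger maximal responses and lower numbers for smaller maximal responses), compound 1 gives 59.9%, and compound 2 gives 58.2%. These two numbers lie within the usual scatter of each other, so the two compounds cannot be told apart on this read-out. Compound 3 `CC1(CCNC(=O)c2ccc(C#Cc3cccc(F)c3)cn2)COC1` has not yet been measured. It differs from compound 2 in a single place: (3-methyloxetan-3-yl)methyl in place of isopropyl on a saturated chain carbon bound to an amide-type nitrogen. Going by the values given here, no measured pair of compounds shows this kind of change, so there is no direct guide to how large an effect it has on the maximal response. Among the compounds with values here, the only hint is that compound 1 and compound 2 carry different groups on the amide-type nitrogen and still give nearly the same number. The expected step of a number 0.2 percentage points lower from compound 2 to compound 3 (within the scatter) is therefore nothing beyond the scatter. Compound 3 is expected to give about 58%, most likely between 42% and 74%.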

Compound 3, largest response reached (reported as efficacy), in percent of the reference or control that the assay uses: 65.7%
Compound 3: the middle estimate sits 7.7 percentage points below what was measured; low and high end bracket the measured number.
By their numbers in this assay, from the lowest: compounds 2, 1 and 3 (each within the scatter of the next).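

In this assay, putting (3-methyloxetan-3-yl)methyl in place of isopropyl on a saturated chain carbon bound to an amide-type nitrogen gives a number 7.5 percentage points higher from compound 2 to compound 3 (within the scatter). This position therefore accepts a group of 6 heavy atoms with a four-membered ring and a hydrogen-bond acceptor in place of one of 3 heavy atoms with neither, and the maximal response stays within the scatter. Nothing available bears on why the step has this size.

The compounds shown leave open whether any group at this position can move the maximal response beyond the scatter, for example an amine, a carboxylic acid or a longer chain. They also leave open whether the same exchange would behave alike with the 2-methylphenyl group of compound 1 in place of the 3-fluorophenyl group.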